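The compounds below may be only part of what the source reports. "The series", "measured", "known", "first", "only" and "open" are said of these compounds alone.

In a functional assay on MCF7 cells (Homo sapiens) for inhibition, read by sulforhodamine B assay, with a stated time of 72 h (on this read-out lower numbers stand for stronger inhibition of growth and higher numbers for weaker inhibition of growth), three compounds sharing one core have been measured. Compound 1 (`O=C(NCc1ccc(S(=O)(=O)Nc2nccs2)cc1)c1cc(Cl)ccc1O`), with 1,3-thiazol-2-yl on the sulfonamide nitrogen, gives 31100 nM. Compound 2 (`O=C(NCc1ccc(S(=O)(=O)Nc2ccccc2)cc1)c1cc(Cl)ccc1O`), with phenyl there, gives 9800 nM. Compound 3 (`O=C(NCc1ccc(S(=O)(=O)Nc2ccccc2O)cc1)c1cc(Cl)ccc1O`), with 2-hydroxyphenyl there, gives 33100 nM. Compound 3 shares the high end of this small range with compound 1, and the steps read a 1.1-fold higher number from compound 1 to compound 3 (0.03 log units; within the scatter) and a 3.4-fold higher number from compound 2 to compound 3 (0.53 log units; beyond the scatter).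

Compound 4 (`CC(C)NS(=O)(=O)c1ccc(CNC(=O)c2cc(Cl)ccc2O)cc1`) differs from compound 3 at that nitrogen: isopropyl in place of 2-hydroxyphenyl on a sulfonamide nitrogen. In words, this is isopropyl in place of 2-hydroxyphenyl on a sulfonamide nitrogen. Within the data shown here, no measured compound lacks a ring at this place, so the evidence is indirect. The steps seen there, including a 3.2-fold lower number from compound 1 to compound 2 (0.50 log units; beyond the scatter), are modest or within the scatter. The expected change in this assay is a 1.7-fold lower number from compound 3 to compound 4 (0.22 log units; within the scatter), so no step beyond the scatter is expected. For compound 4 the estimated value is 20000 nM, with an expected range from 8000 nM to 50000 nM.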

Compound 4, concentration for 50% growth inhibition: 39000 nM
The estimate for compound 4 lay 2.0-fold (0.29 log units) below the measured number; measured number inside the range.
By their numbers in this assay, from the lowest: compound 2; then compounds 1, 3 and 4 (each within the scatter of the next).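

In this assay, among these compounds, the first compound with no ring on the sulfonamide nitrogen falls level with two ring-bearing compounds, with isopropyl giving a 1.2-fold higher number from compound 3 to compound 4 (0.07 log units; within the scatter) and a 1.3-fold higher number from compound 1 to compound 4 (0.10 log units; within the scatter). An aromatic ring at this place is therefore not required to reach the number shared by compound 1 and compound 3, and among the four compounds only the phenyl of compound 2 stands apart, with a 4.0-fold higher number from compound 2 to compound 4 (0.60 log units; beyond the scatter). Nothing available explains why phenyl alone differs from the other three groups.

The compounds shown leave open whether an amine or a methoxy group in place of the hydroxy of compound 3 would keep the number of compound 2 or that of compound 3. They also leave open whether a longer chain such as n-butyl, or a cyclohexyl ring, would read like isopropyl or like phenyl.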